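The source may report more compounds than this note shows. Statements on the series, on what has been measured and on what is new or still open speak of the compounds shown alone.

Measured in an ADME assay on LLC-MK2 cells (Macaca mulatta) for cytotoxicity, read by spectrophotometry and crystal violet staining, with a stated time of 4 days; a lower number here means that less compound is tolerated, a higher number that more compound is tolerated:
compound 1, `CC(C)n1ncc2c(C(=O)Nc3ccncc3)cc(-c3cccs3)nc21`, gives 6300 nM
compound 2, `CC(C)n1ncc2c(C(=O)Nc3ccccc3F)cc(-c3ccncc3)nc21`, gives 45000 nM
compound 3, `CC(C)n1ncc2c(C(=O)Nc3cccnc3)cc(-c3ccsc3)nc21`, gives 37000 nM

Compound 1 stands lowest of the three numbers in this assay. Its nearest neighbour is compound 3, and both that gap and the larger gap to compound 2 lie beyond the scatter of repeated measurements, so compound 1 is the least tolerated of the three. No two of these compounds differ in one place only, so no single step can be read off for a change on the amide-type nitrogen by itself.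

Compound 4, `CC(C)n1ncc2c(C(=O)Nc3cccc(F)c3F)cc(-c3cccs3)nc21`, is not yet measured. It keeps the core of compound 1 and alters the group on the amide-type nitrogen: 2,3-difluorophenyl in place of pyridin-4-yl on an amide-type nitrogen. Among the compounds with values here, with no one-place step to lean on, the expectation for compound 4 in this assay is a small move, not clearly in either direction, and possibly not beyond the scatter. Compound 4 is accordingly expected close to compound 1, estimated at 7000 nM with a range from 2000 nM to 25000 nM. That estimate means an expected step of a 1.1-fold higher number from compound 1 to compound 4 (0.05 log units; within the scatter).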

Compound 4, half-maximal cytotoxic concentration: 75000 nM
Compound 4: middle estimate off by 11-fold (1.03 log units), on the low side, and the stated range ends below it.
By their numbers in this assay, from the lowest: compound 1; then compounds 3, 2 and 4 (each within the scatter of the next, the first and the last beyond it).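

Notes on the group on the amide-type nitrogen: in this assay, 2,3-difluorophenyl in place of pyridin-4-yl gives a 12-fold higher number from compound 1 to compound 4 (1.08 log units; beyond the scatter), the first one-place step in the series and a large one. The low number of compound 1 is therefore not set by the rest of its structure alone, as that structure is unchanged in compound 4 and this one position is enough to shift the number well beyond the scatter. Nothing measured among the data shown accounts for the size of this step.

The change removes the ring nitrogen and brings in two fluorines at once, so the compounds shown do not separate the contribution of either; an unsubstituted phenyl on the same amide-type nitrogen, with the rest of compound 1 kept, would be the direct link between compound 1 and compound 4. As far as these compounds go, it also remains open whether the step holds when the other aromatic group of compound 1 is replaced, and how a pyridin-4-yl ring carrying a methoxy group or an amine would read in this assay.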